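The source may report more compounds than this note shows. Statements on the series, on what has been measured and on what is new or still open speak of the compounds shown alone.

Three compounds have been measured in a functional assay on MCF7 cells (Homo sapiens) for cytotoxicity, read by MTT assay, with a stated time of 72 h; a higher number here means that more compound is tolerated, a lower number that less compound is tolerated:

Compound 1 `COc1ccc(OC(=O)Nc2ccc([Se]C#N)cc2)cc1` gives 74100 nM.
Compound 2 `N#C[Se]c1ccc(NC(=O)Oc2ccc(F)cc2)cc1` gives 65700 nM.
Compound 3 `N#C[Se]c1ccc(NC(=O)Oc2ccc(Cl)cc2)cc1` gives 63600 nM.

Compound 3 holds the smallest of the three numbers, but a 1.2-fold lower number from compound 1 to compound 3 (0.07 log units; within the scatter) and a 1.0-fold lower number from compound 2 to compound 3 (0.01 log units; within the scatter) both lie within the scatter, so the three compounds are not separated by this assay.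

Compound 4 `N#C[Se]c1ccc(NC(=O)Oc2ccccc2)cc1` differs from compound 3 by hydrogen in place of chloro on an aromatic carbon. The same aromatic carbon has already carried methoxy, fluoro and chloro, and every exchange among them stayed flat: a 1.1-fold lower number from compound 1 to compound 2 (0.05 log units; within the scatter), a 1.2-fold lower number from compound 1 to compound 3 (0.07 log units; within the scatter) and a 1.0-fold lower number from compound 2 to compound 3 (0.01 log units; within the scatter). On that basis compound 4 is expected to show no step beyond the scatter, a 1.0-fold higher number from compound 3 to compound 4 (0.02 log units; within the scatter). Compound 4 is therefore estimated at 66000 nM, with a range of 35000 nM to 125000 nM.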

Compound 4, concentration lethal to 50% of the cells: 67800 nM
Compound 4: middle estimate off by 1.0-fold (0.01 log units), on the low side; the range from low to high includes it.
By their numbers in this assay, from the lowest: compounds 3, 2, 4 and 1 (each within the scatter of the next).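

Taking the substituent away altogether changes nothing measurable, which the exchanges among substituents could not show: in this assay the steps to hydrogen are a 1.1-fold higher number from compound 3 to compound 4 (0.03 log units; within the scatter) and a 1.0-fold higher number from compound 2 to compound 4 (0.01 log units; within the scatter) and a 1.1-fold lower number from compound 1 to compound 4 (0.04 log units; within the scatter) and all stay within the scatter. This aromatic carbon therefore does not separate hydrogen from chloro, fluoro or methoxy in these four compounds. Nothing available explains this flatness.

Going by these compounds, it remains open whether an amine, a carboxylic acid or a longer chain on this carbon would give a step beyond the scatter. Changes elsewhere in the shared core also remain open.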